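Hydroxy for methoxy on the styryl arm: a cytotoxicity estimate

The source may hold more compounds than are shown below. What is called first, only, known or untested is meant among the compounds shown, and "the series" means these compounds.

Measured so far, in an ADME assay on the whole organism for cytotoxicity, with Artemia salina as the target, with a stated time of 24 h; a higher number here means that more compound is needed for the effect, a lower number that less compound is needed:
Compound 1 `COc1cccc(/C=C/C(=O)c2ccccc2NC(=O)NS(=O)(=O)c2ccc(C)cc2)c1` gives 23.2 ug/mL.
Compound 2 `CCc1cc(/C=C/C(=O)c2ccccc2NC(=O)NS(=O)(=O)c2ccc(C)cc2)cc(OC)c1OC` gives 19.2 ug/mL.
Compound 3 `Cc1ccc(S(=O)(=O)NC(=O)Nc2ccccc2C(=O)/C=C/c2cccc(O)c2)cc1` gives 39.3 ug/mL.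

Compound 1 stands second highest of these three numbers. Its nearest neighbour is compound 2, with a 1.2-fold lower number from compound 1 to compound 2 (0.08 log units; within the scatter), and its furthest is compound 3, with a 1.7-fold higher number from compound 1 to compound 3 (0.23 log units; within the scatter). For the measured compounds named here, the only step read as beyond the scatter is a 2.0-fold higher number from compound 2 to compound 3 (0.31 log units; beyond the scatter), and it is a modest one.

The unmeasured compound 4 `Cc1ccc(S(=O)(=O)NC(=O)Nc2ccccc2C(=O)/C=C/c2ccc(O)cc2)cc1` differs from compound 1 in one place: 4-hydroxyphenyl in place of 3-methoxyphenyl on a double-bonded chain carbon bound to a double-bonded chain carbon. The step that bears most directly on this change is a 1.7-fold higher number from compound 1 to compound 3 (0.23 log units; within the scatter), where the same oxygen loses its methyl while the ring substituent keeps its position; that step stayed within the scatter. The step from compound 2 to compound 3 also exchanges a methoxy-bearing ring for a hydroxyphenyl and gave a modest rise. Going by the values given here, no measured pair speaks to the 4-hydroxyphenyl arrangement itself.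

On this basis a small rise, or no step beyond the scatter, is expected in this assay for compound 4, that is a 1.5-fold higher number from compound 1 to compound 4 (0.18 log units; within the scatter). Compound 4 is therefore estimated at 35 ug/mL, within a range from 18 ug/mL to 70 ug/mL.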

Compound 4, concentration for half-maximal effect: 24.3 ug/mL
The estimate for compound 4 lay 1.4-fold (0.16 log units) above the measured number, and the stated range covers the measured number.
By their numbers in this assay, from the lowest: compounds 2, 1, 4 and 3 (each within the scatter of the next, the first and the last beyond it).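

Compound 4 shows that a hydroxy group can stand in the 4-hydroxyphenyl arrangement on a double-bonded chain carbon bound to a double-bonded chain carbon with no step beyond the scatter in this assay: replacing 3-methoxyphenyl gives a 1.0-fold higher number from compound 1 to compound 4 (0.02 log units; within the scatter) and so leaves the number in place. Moving the hydroxy group gives a 1.6-fold lower number from compound 3 to compound 4 (0.21 log units; within the scatter) in the same test, so this assay does not separate 4-hydroxyphenyl from 3-hydroxyphenyl. The exchange of 3-ethyl-4,5-dimethoxyphenyl for 4-hydroxyphenyl gives a 1.3-fold higher number from compound 2 to compound 4 (0.10 log units; within the scatter) as well, which leaves a 2.0-fold higher number from compound 2 to compound 3 (0.31 log units; beyond the scatter) as the only step beyond the scatter among these four compounds, and that step is a modest one.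

No measurement shown here offers an explanation for these numbers. Still open, as far as these compounds go, is how the number would respond to a 4-methoxyphenyl group, which would complete the comparison of hydroxy and methoxy in this arrangement, or to an amine, a carboxylic acid or a longer chain on this ring.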